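Widening the bridged ring group of compound 3

The source may hold more compounds than are shown below. What is called first, only, known or untested is meant among the compounds shown, and "the series" means these compounds.

In a functional assay on A-375 cells (Homo sapiens) for inhibition, read by MTT assay, with a stated time of 4 days (on this read-out higher numbers stand for weaker inhibition and lower numbers for stronger inhibition), compound 1 `CN1C[C@@H]2CC[C@H]1CN2c1ccc(-c2ccnc3c(-c4cccc5[nH]ncc45)c(-c4ccncc4)nn23)c(F)c1` gives 118 nM. Compound 2 `Fc1cc(CN2C[C@@H]3C[C@H]2CO3)ccc1-c1ccnc2c(-c3cccc4[nH]ncc34)c(-c3ccncc3)nn12` gives 268 nM, and its mirror image, compound 3 `Fc1cc(CN2C[C@H]3C[C@@H]2CO3)ccc1-c1ccnc2c(-c3cccc4[nH]ncc34)c(-c3ccncc3)nn12`, gives 78 nM. Compound 3 thus stands level with compound 1, at a 1.5-fold lower number from compound 1 to compound 3 (0.18 log units; within the scatter), and apart from compound 2, at a 3.4-fold lower number from compound 2 to compound 3 (0.54 log units; beyond the scatter). That second step is traced to the fact that compounds 2 and 3 differ only in the configuration as drawn.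

Compound 4 `Fc1cc(CN2C3COCC2COC3)ccc1-c1ccnc2c(-c3cccc4[nH]ncc34)c(-c3ccncc3)nn12` carries a new group on the saturated chain carbon bound to an aromatic carbon: a group of 9 heavy atoms (6 carbon, 1 nitrogen, 2 oxygen; 2 six-membered non-aromatic rings with 2 hetero atoms each) in place of a group of 7 heavy atoms (5 carbon, 1 nitrogen, 1 oxygen; 2 five-membered non-aromatic rings with 1 hetero atom each), on a saturated chain carbon bound to an aromatic carbon. The group that leaves has 2 defined stereocentres.

Among the compounds with values here, no measured step makes this exact exchange. The nearest are the group exchanges, a 2.3-fold higher number from compound 1 to compound 2 (0.36 log units; beyond the scatter) and a 1.5-fold lower number from compound 1 to compound 3 (0.18 log units; within the scatter), which stayed modest or inside the scatter. The mirror-image pair shows that the group's arrangement can still matter, so a small rise in this assay is expected rather than a large one. The expected change is a 1.5-fold higher number from compound 3 to compound 4 (0.19 log units; within the scatter). Compound 4 is estimated at 120 nM, with an expected range of 40 nM to 350 nM.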

Compound 4, half-maximal inhibitory concentration: 304 nM
Estimate against measurement, compound 4: 2.5-fold (0.40 log units) below; the range from low to high includes it.
By their numbers in this assay, from the lowest: compounds 3 and 1 (each within the scatter of the next); then compounds 2 and 4 (each within the scatter of the next).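

In this assay, the exchange on the saturated chain carbon bound to an aromatic carbon takes the series away from the level of compound 3, at a 3.9-fold higher number from compound 3 to compound 4 (0.59 log units; beyond the scatter). Measured against the other mirror image, the same exchange leaves the number level, at a 1.1-fold higher number from compound 2 to compound 4 (0.05 log units; within the scatter), so the size of the step at this position depends on the starting mirror image, and the gap between those two starting points is traced to configuration alone: the fact that compounds 2 and 3 differ only in the configuration as drawn. Compound 3 stood level with compound 1, but the new group stands apart from it, at a 2.6-fold higher number from compound 1 to compound 4 (0.41 log units; beyond the scatter).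

Compound 4 changes ring size and adds a ring oxygen at once, so the compounds shown cannot say which of the two goes with the rise. Nor do they show how a plain morpholine or piperidine in the same place would read in this assay.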